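A few compounds are considered here, and "the series" means these few. Any claim that something is new, unique, unknown or untested is made for them only; others in the source may bear on it.

Measured compounds in a functional assay on HeLa cells (Homo sapiens) for antiproliferative activity, read by sulforhodamine B assay, with a stated time of 48 h; on this read-out lower numbers stand for stronger inhibition and higher numbers for weaker inhibition:
- compound 1 `Nc1ccc(S(=O)(=O)Nc2ccnc3cc(C(F)(F)F)ccc23)cc1`: 46000 nM
- compound 2 `O=C(Nc1ccccc1)Nc1ccc(S(=O)(=O)Nc2ccnc3cc(C(F)(F)F)ccc23)cc1`: 41000 nM
- compound 3 `Cc1cc(NS(=O)(=O)c2ccc(N/C(S)=N\c3ccnc4cc(C(F)(F)F)ccc34)cc2)on1`: 60200 nM

All three numbers sit close together; compound 3 differs from compound 1 and from compound 2 only within the scatter, so no ranking among the three is supported. Within the data shown here, the one measured step, a 1.1-fold lower number from compound 1 to compound 2 (0.05 log units; within the scatter), concerns phenylcarbamoyl in place of hydrogen on an aromatic amine and stays within the scatter.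

Compound 4 `O=S(=O)(Nc1ccccn1)c1ccc(N/C(S)=N\c2ccnc3cc(C(F)(F)F)ccc23)cc1` has not yet been measured in this assay. It differs from compound 3 as follows: pyridin-2-yl in place of 3-methyl-1,2-oxazol-5-yl on a sulfonamide nitrogen. Among the measured compounds shown here, no measured pair bears on an exchange at the sulfonamide nitrogen, and the only measured step, at a different position, was within the scatter. The shared core therefore gives no ground to expect a step beyond the scatter in either direction. Compound 4 is expected to land near compound 3, with an estimated step of a 1.2-fold lower number from compound 3 to compound 4 (0.08 log units; within the scatter). The estimate for compound 4 is 50000 nM, with a range from 20000 nM to 150000 nM.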

Compound 4, half-maximal inhibitory concentration: 68800 nM
The estimate for compound 4 lay 1.4-fold (0.14 log units) below the measured number; the measured number falls inside the stated range.
By their numbers in this assay, from the lowest: compounds 2, 1, 3 and 4 (each within the scatter of the next).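

In this assay, among these compounds, pyridin-2-yl in place of 3-methyl-1,2-oxazol-5-yl on a sulfonamide nitrogen gives a 1.1-fold higher number from compound 3 to compound 4 (0.06 log units; within the scatter), the only measured step at this position. A five-membered aromatic ring with 2 hetero atoms and a six-membered aromatic ring with 1 hetero atom are therefore not told apart at this nitrogen by this read-out. Nothing available on these compounds offers an explanation for this result.

The compounds shown leave open whether a group other than an aromatic ring on the sulfonamide nitrogen, such as a plain hydrogen, a methyl or a longer chain ending in a carboxylic acid, would give a step beyond the scatter. Also open, as far as these compounds go, is whether any change to the shared core would do so in this assay.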